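Methyl for hydrogen on the benzyl ring of compound 3

This account rests on a few compounds, and the source may have more. Where it says the series, first, only, none or still open, it means among the compounds named here.

The three measured compounds share one core and differ only in the benzyl group on the ring nitrogen. In an assay on isolated protein for displacement of a labelled ligand from Orexin/Hypocretin receptor type 1 (Homo sapiens), with a stated time of 90 min (a lower number here means a stronger inhibitor, a higher number a weaker inhibitor), compound 1 `COc1ccc(N2C(=O)N(Cc3c(F)cc(F)cc3F)c3ccccc3S2(=O)=O)cc1OC` gives 50.1 nM. Compound 2 `COc1cc(F)c(CN2C(=O)N(c3ccc(OC)c(OC)c3)S(=O)(=O)c3ccccc32)c(Cl)c1` gives 0.398 nM in this assay. Compound 3 `COc1ccc(N2C(=O)N(Cc3c(F)cccc3Cl)c3ccccc3S2(=O)=O)cc1OC` gives 7.94 nM in this assay. Compound 3 therefore holds the second highest of the three numbers: the step was a 6.3-fold lower number from compound 1 to compound 3 (0.80 log units; beyond the scatter), and the step was a 20-fold higher number from compound 2 to compound 3 (1.30 log units; beyond the scatter).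

Compound 4 `COc1ccc(N2C(=O)N(Cc3c(F)cc(C)cc3Cl)c3ccccc3S2(=O)=O)cc1OC` differs from compound 3 by methyl in place of hydrogen on an aromatic carbon. The step most directly bearing on this is a 20-fold higher number from compound 2 to compound 3 (1.30 log units; beyond the scatter), where the same aromatic carbon carries methoxy in compound 2 and hydrogen in compound 3; read in the direction hydrogen to methoxy it is a large drop in the number. The steps of a 130-fold lower number from compound 1 to compound 2 (2.10 log units; beyond the scatter) and a 6.3-fold lower number from compound 1 to compound 3 (0.80 log units; beyond the scatter) also show that substitution on this ring moves the number well beyond the scatter. A methyl group is not a methoxy group, so the drop is expected to be smaller, but still beyond the scatter and in the same direction. For compound 4 the expected step is a 4.0-fold lower number from compound 3 to compound 4 (0.60 log units; beyond the scatter), giving an estimate of 2 nM with a range from 0.5 nM to 8 nM.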

Compound 4, inhibition constant: 6.31 nM
For compound 4 the middle estimate is 3.2-fold (0.50 log units) below the measured one, within the range that was stated.
By their numbers in this assay, from the lowest: compound 2; then compounds 4 and 3 (each within the scatter of the next); then compound 1.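

In this assay, going by these compounds alone, methyl in place of hydrogen on the aromatic carbon para to a large group gives a 1.3-fold lower number from compound 3 to compound 4 (0.10 log units; within the scatter) and so does not reproduce the large step seen for methoxy at the same carbon; the earlier compounds showed only that hydrogen and methoxy differ here, and did not show whether any added group would do the same. The comparison of methyl with methoxy at this carbon gives a 16-fold higher number from compound 2 to compound 4 (1.20 log units; beyond the scatter) and places compound 2 clearly apart, so among hydrogen, methyl and methoxy at this carbon only methoxy gives a number beyond the scatter of the others. The 2-chloro-6-fluoro-4-methylphenyl group still differs from 2,4,6-trifluorophenyl by a 7.9-fold lower number from compound 1 to compound 4 (0.90 log units; beyond the scatter) and this step is of the same modest class as a 6.3-fold lower number from compound 1 to compound 3 (0.80 log units; beyond the scatter) in the series.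

On these data alone, whether ethoxy, hydroxy or an amine on this carbon would fall with compound 2 or with compounds 3 and 4 remains open. No measurement in hand accounts for the gap between methyl and methoxy at this carbon.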